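A few compounds are considered here, and "the series" means these few. Any claim that something is new, unique, unknown or untested is made for them only; others in the source may bear on it.

Measured so far:
compound 1, `CNC(=O)CCc1cn(-c2ccc(Br)cc2)nc1-c1ccc(Cl)cc1`: < 5000 nM
compound 2, `CN(C(=O)CCc1cn(-c2ccc(Br)cc2)nc1-c1ccc(Cl)cc1)S(C)(=O)=O`: < 5000 nM

In a physicochemical assay for solubility, in phosphate buffer, measured as thermodynamic solubility, at pH 7.4 (a lower number here means a less soluble compound, a higher number a more soluble compound), compound 1 gives < 5000 nM, which is a limit of the assay and not a number. In this assay compound 2 likewise gives < 5000 nM, again a limit rather than a measured number. Compound 2 therefore stands at the floor of what has been recorded here; (the limit of < 5000 nM in this assay, at which 2 of the 2 values shown sit), so no ordering between the two compounds can be read. Among the compounds with values here, the one measured step, a step that the two limits leave unreadable from compound 1 to compound 2, is unreadable for the same reason.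

Compound 3, `CS(=O)(=O)NCCCc1cn(-c2ccc(Br)cc2)nc1-c1ccc(Cl)cc1`, is not yet measured. It differs from compound 2 in one place: (methanesulfonamido)methyl in place of methyl(methylsulfonyl)carbamoyl on a saturated chain carbon, two bonds along the chain from an aromatic carbon. Within the data shown here, no measured step speaks readably to this change, so the expectation for compound 3 rests only on where compound 2 stands. Compound 3 is estimated at 3000 nM, within 500 nM to 20000 nM, which means an expected step that the limit leaves unreadable from compound 2 to compound 3.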

Compound 3, solubility: < 5000 nM
Compound 3: a limit, no number; the forecaster's own chance of this, stated with the estimate: 65%; the middle value does not contradict the limit.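

In this assay compound 3 gives < 5000 nM, which is a limit of the assay and not a number. No step among compound 1, compound 2 and compound 3 can therefore be read: the limit of < 5000 nM in this assay, at which 3 of the 3 values shown sit.

The compounds shown leave open how the solubility of these three compounds compares.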